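Adding a Methoxymethyl Group to a Compound at the Limit

The source may hold more compounds than are shown below. What is called first, only, known or untested is meant among the compounds shown, and "the series" means these compounds.

Compound 1 `O=c1cc(CC(O)COCc2ccccc2)[nH]c(=O)[nH]1` is the parent of this small set. In a functional assay on SW-620 cells (Homo sapiens) for antiproliferative activity, read by MTT assay, with a stated time of 72 h (a higher number here means a weaker inhibitor, a lower number a stronger inhibitor), compound 1 gives only a limit, > 100000 nM. Compound 2 `Cc1c(CC(O)COCc2ccccc2)[nH]c(=O)[nH]c1=O` carries a methyl in place of hydrogen on an aromatic carbon, and in this assay compound 2 likewise gives a limit, > 100000 nM. Compound 3 `C[Si](C)(C)CCOCn1c(CC(O)COCc2ccccc2)cc(=O)[nH]c1=O` adds a larger group on an aromatic nitrogen; in this assay compound 3 also reaches only a limit, > 100000 nM. The steps a step that the two limits leave unreadable from compound 1 to compound 2 and a step that the two limits leave unreadable from compound 1 to compound 3 cannot be sized because of the limit of > 100000 nM in this assay, at which 3 of the 3 values shown sit. Compound 4 `COCn1c(CC(O)COCc2ccccc2)c(C)c(=O)[nH]c1=O` differs from compound 2 by methoxymethyl in place of hydrogen on an aromatic nitrogen. Among the measured compounds shown here, no measured step bears readably on this change. Compound 4 is expected to stay at the same limit, an estimated 100000 nM with a range from 30000 nM to 300000 nM, so the expected step of a number no higher from compound 2 to compound 4 (the limit leaves the size open) is none beyond the scatter.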

Compound 4, half-maximal inhibitory concentration: > 100000 nM
Compound 4: no number, only a limit (the forecaster's own chance of this, stated with the estimate: 85%); the middle value sits exactly at the limit.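

Among the compounds shown here, compound 2 and compound 4 both give only a limit, so no step between them can be read, because of where every value falls: the limit of > 100000 nM in this assay, at which 4 of the 4 values shown sit.

Going by these compounds, whether methoxymethyl changes the strength of compound 2 in this assay stays open.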